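The source may report more compounds than this note shows. Statements on the series, on what has been measured and on what is new or still open speak of the compounds shown alone.

Measured in a functional assay on MV4-11 cells (Homo sapiens) for inhibition, read by resazurin assay, with a stated time of 72 h; a higher number here means a weaker inhibitor of growth, a lower number a stronger inhibitor of growth:
- Compound 1 `O=C1NCCC12CCN(c1c(Cl)cncc1-c1cc[nH]c1)CC2`: 1050 nM
- Compound 2 `Cc1ccsc1-c1cncc(Cl)c1N1CCC2(CCNC2=O)CC1`: 910 nM
- Compound 3 `Cn1cccc1-c1cncc(Cl)c1N1CCC2(CCNC2=O)CC1`: 900 nM

In this assay, compound 3 at 900 nM lies within the scatter of both compound 1 and compound 2, so the three cannot be ranked. The next compound, compound 4 `O=Cc1cscc1-c1cncc(Cl)c1N1CCC2(CCNC2=O)CC1`, carries 4-formylthiophen-3-yl in place of 1-methyl-1H-pyrrol-2-yl on an aromatic carbon, and the count of the exchange reads (4-formylthiophen-3-yl in place of 1-methyl-1H-pyrrol-2-yl on an aromatic carbon).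

The three measured steps bear on this change, since each swaps one group with a five-membered aromatic ring for another at the same place. They are a 1.2-fold lower number from compound 1 to compound 2 (0.06 log units; within the scatter), a 1.2-fold lower number from compound 1 to compound 3 (0.07 log units; within the scatter) and a 1.0-fold lower number from compound 2 to compound 3 (0.00 log units; within the scatter). All three are small and within the scatter. From the compounds shown here alone, none of the three measured compounds carries a formyl group, however, so this part of the change is untested and the range is kept wide.

On the evidence of these steps, the expected change is no larger than the scatter, and the estimated step is no change at the digits printed from compound 3 to compound 4 (within the scatter). For compound 4 the estimated value in this assay is 900 nM, with an expected range from 420 nM to 1900 nM.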

Compound 4, concentration for 50% growth inhibition: 27100 nM
Compound 4: middle estimate off by 30-fold (1.48 log units), on the low side; measured number above the stated range.
By their numbers in this assay, from the lowest: compounds 3, 2 and 1 (each within the scatter of the next); then compound 4.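

In this assay this place, on an aromatic carbon ortho to a large group and meta to a chloro group, turns out not to accept every five-membered aromatic ring: 4-formylthiophen-3-yl gives a 30-fold higher number from compound 3 to compound 4 (1.48 log units; beyond the scatter), along with a 30-fold higher number from compound 2 to compound 4 (1.47 log units; beyond the scatter) and a 26-fold higher number from compound 1 to compound 4 (1.41 log units; beyond the scatter), all beyond the scatter. The earlier compounds shown here, with 1H-pyrrol-3-yl, 3-methylthiophen-2-yl and 1-methyl-1H-pyrrol-2-yl, stayed within the scatter of one another, and since compound 2 also carries a thiophene, a sulfur-containing ring alone does not go with the much higher number of compound 4. Nothing measured in this set accounts for the loss.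

Compound 4 differs from compound 2 both in the ring's point of attachment and in the formyl group, so the compounds shown do not separate these two parts of the change. From the compounds shown here alone, it remains open whether plain thiophen-3-yl would stand with compounds 1, 2 and 3 or with compound 4, and whether a hydroxymethyl group or a carboxylic acid in place of the formyl group would keep the higher number.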